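Swapping a Chain Tail for a Lactam on the Core

This account rests on a few compounds, and the source may have more. Where it says the series, first, only, none or still open, it means among the compounds named here.

Measured in an in vitro assay on CHO-K cells with growth hormone secretagogue receptor type 1 (Homo sapiens) as the target; on this read-out lower numbers stand for stronger inhibition and higher numbers for weaker inhibition:
Compound 1 `CCCc1onc(-c2c(Cl)cccc2Cl)c1C(=O)Nc1ccc(N(CC)CC)cc1`: 131 nM
Compound 2 `CCN(CC)c1ccc(NC(=O)c2c(-c3c(Cl)cccc3Cl)noc2CCC2CCCCO2)cc1`: 39 nM

Compound 2 gives the lower of the two numbers, and the step of a 3.4-fold lower number from compound 1 to compound 2 (0.53 log units; beyond the scatter) lies beyond the scatter. Compound 3 `CCN(CC)c1ccc(NC(=O)c2c(-c3c(Cl)cccc3Cl)noc2CN2CCCC2=O)cc1` differs from compound 2 in one place: 2-oxopyrrolidin-1-yl in place of (oxan-2-yl)methyl on a saturated chain carbon bound to an aromatic carbon. For the measured compounds named here, only that one measured step touches this region, and it concerns a different change, so it gives little guidance; the expected step is small, toward a higher number, within or just beyond the scatter. Compound 3 is expected at 70 nM, with a range from 20 nM to 250 nM, an expected step of a 1.8-fold higher number from compound 2 to compound 3 (0.25 log units; within the scatter).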

Compound 3, half-maximal inhibitory concentration: 122 nM
Compound 3: middle estimate off by 1.7-fold (0.24 log units), on the low side, within the range that was stated.
By their numbers in this assay, from the lowest: compound 2; then compounds 3 and 1 (each within the scatter of the next).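

Of the two ring-bearing groups, 2-oxopyrrolidin-1-yl does not keep what (oxan-2-yl)methyl gave on this saturated chain carbon, with a 3.1-fold higher number from compound 2 to compound 3 (0.50 log units; beyond the scatter) in this assay here. Against the plain ethyl, the same group gives a 1.1-fold lower number from compound 1 to compound 3 (0.03 log units; within the scatter) and so reads no differently from that ethyl. No measurement here says why the two rings differ.

The step swaps the ring and the length of its link together, leaving open which of the two matters. Equally open, as far as these compounds go, is how the same lactam on a longer chain, or a simple amine, would read at this place.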